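Ester Series on a Shared Core: Nitro Replaces Methoxy

This account rests on a few compounds, and the source may have more. Where it says the series, first, only, none or still open, it means among the compounds named here.

Compound 1 `Cc1cc2c(C(C)C)ccc(C)c2cc1OC(=O)c1cccc(C(F)(F)F)c1`: 26.7%
Compound 2 `Cc1cc2c(C(C)C)ccc(C)c2cc1OC(=O)c1ccc(C(F)(F)F)cc1`: 100%
Compound 3 `COc1cccc(C(=O)Oc2cc3c(C)ccc(C(C)C)c3cc2C)c1`: 12.5%

All three compounds share one core and differ only in the substituted phenyl ring attached to the ester carbonyl. In a functional assay on PC-3 cells (Homo sapiens) for antiproliferative activity, read by sulforhodamine B assay, with a stated time of 48 h, tested at 50 uM (on this read-out higher numbers stand for more inhibition at the one concentration tested (going by the name of the read-out) and lower numbers for less inhibition), compound 2 gives 100%, while compound 1 gives 26.7% and compound 3 gives 12.5%. Compound 3 thus stands lowest of the three, and its distance to each of the others is beyond the scatter.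

Among the compounds with values here, the one step that can be traced exactly runs from compound 1 to compound 3: a number 14.2 percentage points lower from compound 1 to compound 3 (beyond the scatter).

Compound 4 `Cc1cc2c(C(C)C)ccc(C)c2cc1OC(=O)c1ccc([N+](=O)[O-])cc1` has not yet been measured. It differs from compound 3 in one place: 4-nitrophenyl in place of 3-methoxyphenyl on a carbonyl carbon. Within the data shown here, no measured step swaps a methoxy group for a nitro group, so the direction of this change cannot be read from a single matched pair. What the numbers do show is that compound 3 sits at the bottom of the series, and that compound 2 gives a higher number. The step expected here is estimated as a number 37.5 percentage points higher from compound 3 to compound 4 (beyond the scatter). The uncertainty of this expectation is wide.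

Compound 4 is estimated to give 50% in this assay, within a range of 10% to 95%.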

Compound 4, a percentage reported as inhibition, at one concentration (the size of the read-out at that concentration, not a potency): 100%
For compound 4 the middle estimate is 50 percentage points below the measured one, outside the stated range (above it).
By their numbers in this assay, from the lowest: compound 3; then compound 1; then compounds 2 and 4 (each within the scatter of the next).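

In this assay, putting 4-nitrophenyl in place of 3-methoxyphenyl on the carbonyl carbon gives a number 87.5 percentage points higher from compound 3 to compound 4 (beyond the scatter) and so moves the reading from the bottom of the series to the top of it. Nitro in place of trifluoromethyl on an aromatic carbon gives no change at the digits printed from compound 2 to compound 4 (within the scatter) and shows that two different groups can give the same high reading on this ring. Compound 1, at 26.7% in this assay, also carries trifluoromethyl, so the presence of that group does not by itself go with a high number in this small set. No measurement shown here explains these differences.

The step between compound 3 and compound 4 changes both the group and the number in its name, so the compounds shown cannot separate the effect of swapping methoxy for nitro from that of moving the group on the ring. On these data alone, it also remains open whether an amine or a carboxylic acid on this ring would give a high reading, and whether compound 2 and compound 4 would differ at lower concentrations, since one concentration gives no potency.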